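From tert-butyl to phenyl: a small step expected

A few compounds are considered here, and "the series" means these few. Any claim that something is new, unique, unknown or untested is made for them only; others in the source may bear on it.

Measured in an ADME assay on WI-38 cells (Homo sapiens) for cytotoxicity, read by MTT assay, with a stated time of 72 h; a higher number here means a weaker inhibitor, a lower number a stronger inhibitor
- compound 1 `O=C(CCc1cccc2c1B(O)OC2)Nc1ccc(Br)cc1` gives 42000 nM
- compound 2 `CC(C)(C)c1ccc(NC(=O)CCc2cccc3c2B(O)OC3)cc1` gives 55000 nM
- compound 3 `O=C(CCc1cccc2c1B(O)OC2)Nc1ccc2ccccc2c1` gives > 100000 nM (a limit, not a number)

Only two of these three results are true numbers, and compound 2 lies close to compound 1, with a 1.3-fold higher number from compound 1 to compound 2 (0.12 log units; within the scatter) as the step between them. Compound 3 stands at the limit of > 100000 nM in this assay, at which 1 of the 3 values shown sits, so it offers no number for comparison.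

Compound 4 `O=C(CCc1cccc2c1B(O)OC2)Nc1ccc(-c2ccccc2)cc1` keeps the shared core and carries phenyl in place of tert-butyl on an aromatic carbon . For the measured compounds named here, one measured step bears on this change: replacing bromo with tert-butyl on an aromatic carbon gave a 1.3-fold higher number from compound 1 to compound 2 (0.12 log units; within the scatter), so that swap from compound 1 left the result within the scatter. One step is thin evidence, but it gives no reason to expect a large move here. The expected size of the change is a 1.1-fold higher number from compound 2 to compound 4 (0.04 log units; within the scatter), which would be no step beyond the scatter in either direction. Compound 4 may also be reported only as a limit, as compound 3 is. For compound 4 the estimated value is 60000 nM, with an expected range from 25000 nM to 100000 nM.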

Compound 4, half-maximal inhibitory concentration: 32000 nM
The estimate for compound 4 lay 1.9-fold (0.27 log units) above the measured number; the measured number falls inside the stated range.
By their numbers in this assay, from the lowest: compounds 4, 1 and 2 (each within the scatter of the next). At a limit, above all of these: compound 3.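

At this place on the six-membered aromatic ring, this assay now has a ring-bearing group to set against two groups without a ring, and the swap of tert-butyl for phenyl gives a 1.7-fold lower number from compound 2 to compound 4 (0.24 log units; within the scatter), while the swap of bromo for phenyl gives a 1.3-fold lower number from compound 1 to compound 4 (0.12 log units; within the scatter). Neither step leaves the scatter, so bringing in a six-membered aromatic ring of carbon only, with six heavy atoms where tert-butyl has four, shows no measurable effect on this read-out, and bromo, tert-butyl and phenyl cannot be put in any order here. Nothing in the data gives a reason why these three groups read alike.

Compound 3 gives > 100000 nM, which is a limit and not a number, so the steps to it cannot be read. Also open, as far as these compounds go, is whether an amine or a carboxylic acid at this same place, with its hydrogen-bond donors or acceptors, would give a step beyond the scatter, as all three groups compared so far stay within it.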